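Swapping the Ethyl on the Piperazine Nitrogen

The compounds below may be only part of what the source reports. "The series", "measured", "known", "first", "only" and "open" are said of these compounds alone.

Compound 1 `Cn1c(-c2ccc(NC(=O)CSc3nc4ccccc4o3)cc2)nc(-c2ccccc2)c1-c1ccccc1`: 71.5%
Compound 2 `CCN1CCN(CC(=O)Nc2ccc(-c3nc(-c4ccccc4)c(-c4ccccc4)n3C)cc2)CC1`: 38.6%

For the measured compounds named here, in a functional assay on MCF7 cells (Homo sapiens) for cytotoxicity, read by MTT assay, with a stated time of 24 h, tested at 32 ug/mL (a higher number here means a stronger effect of the compound at the concentration tested, a lower number a weaker effect), compound 2 gives the lower of the two numbers measured so far, and compound 1 gives the higher. Going by the values given here, the one measured step, a number 32.9 percentage points lower from compound 1 to compound 2 (beyond the scatter), concerns a different part of the molecule.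

Compound 3 `CN(C)/C=C/N1CCN(CC(=O)Nc2ccc(-c3nc(-c4ccccc4)c(-c4ccccc4)n3C)cc2)CC1` carries the change (2-(dimethylamino)ethenyl in place of ethyl on an amine nitrogen in a ring). Among the compounds with values here, no measured step touches the 4-ethylpiperazin-1-yl group, so nothing known bears on this change; the step of a number 1.4 percentage points higher from compound 2 to compound 3 (within the scatter) is expected to stay within the scatter. Compound 3 is therefore estimated at 40%, between 25% and 57%.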

Compound 3, a percentage reported as activity, at one concentration (the size of the read-out at that concentration, not a potency): 25.8%
Estimate against measurement, compound 3: 14.2 percentage points above; the measured number falls inside the stated range.
By their numbers in this assay, from the lowest: compound 3; then compound 2; then compound 1.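

In this assay, the group on this amine nitrogen in a ring does matter: 2-(dimethylamino)ethenyl in place of ethyl gives a number 12.8 percentage points lower from compound 2 to compound 3 (beyond the scatter). Putting 4-(2-(dimethylamino)ethenyl)piperazin-1-yl in place of (1,3-benzoxazol-2-yl)sulfanyl gives a number 45.7 percentage points lower from compound 1 to compound 3 (beyond the scatter), a step that is large. Nothing measured here explains why the number falls. Still open, on these data alone, is how a saturated 2-(dimethylamino)ethyl chain or a propyl chain on the same nitrogen would compare, which could separate the effect of the double bond from that of the added amine.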